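Replacing the 4-methylphenyl group of compound 2

The source may report more compounds than this note shows. Statements on the series, on what has been measured and on what is new or still open speak of the compounds shown alone.

Compound 1 `CC1(C)[C@H]2CC[C@]1(C)N(Cc1cn(-c3ccc(F)cc3)nn1)C(=O)C2` - 200 nM
Compound 2 `Cc1ccc(-n2cc(CN3C(=O)C[C@@H]4CC[C@@]3(C)C4(C)C)nn2)cc1` - 40 nM

In a functional assay on OVCAR-3 cells (Homo sapiens) for inhibition, read by MTT assay, with a stated time of 24 h (on this read-out lower numbers stand for stronger inhibition and higher numbers for weaker inhibition), only these two compounds have been measured, and compound 2 stands lowest of the two at 40 nM. Compound 3 `CC1(C)[C@H]2CC[C@]1(C)N(Cc1cn(-c3cccc(O)c3)nn1)C(=O)C2` is the next to be tested. It keeps the shared core and carries 3-hydroxyphenyl in place of 4-methylphenyl on an aromatic nitrogen of a five-membered aromatic ring with 3 nitrogen: 3-hydroxyphenyl in place of 4-methylphenyl on an aromatic nitrogen. Among the compounds with values here, one measured step bears on this change: a 5.0-fold lower number from compound 1 to compound 2 (0.70 log units; beyond the scatter), with methyl in place of fluoro on an aromatic carbon. That step is modest but beyond the scatter, and it shows that this assay responds to a change on this aromatic ring. Within the data shown here, no measured compound carries a 3-hydroxyphenyl group, so the evidence is indirect. Among the measured compounds shown here, the only other group measured here, in compound 1 at 200 nM, gave a higher number, so a modest rise is expected. The expected move is a 3.0-fold higher number from compound 2 to compound 3 (0.48 log units; beyond the scatter), an estimate of similar size to the measured step. For compound 3 the estimated value is 120 nM, with an expected range from 30 nM to 500 nM.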

Compound 3, half-maximal inhibitory concentration: 370 nM
For compound 3 the middle estimate is 3.1-fold (0.49 log units) below the measured one; the measured number falls inside the stated range.
By their numbers in this assay, from the lowest: compound 2; then compounds 1 and 3 (each within the scatter of the next).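

In this assay, 3-hydroxyphenyl in place of 4-methylphenyl on the aromatic nitrogen gives a 9.3-fold higher number from compound 2 to compound 3 (0.97 log units; beyond the scatter), which shows that this position can lose much of the low number reached with 4-methylphenyl. Set against the 4-fluorophenyl group, 3-hydroxyphenyl gives a 1.9-fold higher number from compound 1 to compound 3 (0.27 log units; within the scatter), which lies within the scatter, so this assay does not separate these two groups, and of the three groups tested only 4-methylphenyl stands apart, with steps beyond the scatter to both others. Nothing available explains why the numbers fall this way.

The compounds shown leave open how much of the step from 4-methylphenyl belongs to the hydroxy group itself and how much to where the group sits on the ring, since the two groups differ in both respects. They also leave open whether a phenyl ring bearing an amine, a methoxy group or a longer alkyl chain would stay close to the number of compound 2 or move towards those of the other two compounds.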